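Isobutyl to sec-Butyl on an Amine Nitrogen

A few compounds are considered here, and "the series" means these few. Any claim that something is new, unique, unknown or untested is made for them only; others in the source may bear on it.

Measured so far:
compound 1 `CC(C)CNC(=C\C(=O)/C=C/c1ccc(O)cc1)/C=C/c1ccc(O)cc1`: > 25000 nM
compound 2 `COc1cc(/C=C/C(=O)/C=C(/C=C/c2ccc(OC(C)=O)c(OC)c2)NCC(C)C)ccc1OC(C)=O`: > 25000 nM
compound 3 `CCC(C)NC(=C\C(=O)/C=C/c1ccc(O)cc1)/C=C/c1ccc(O)cc1`: > 25000 nM

In an ADME assay on Caco-2 cells (Homo sapiens) for inhibition, read by MTT assay, with a stated time of 72 h (a higher number here means a weaker inhibitor, a lower number a stronger inhibitor), compound 1 gives > 25000 nM, which is a limit of the assay rather than a number. In this assay compound 2 gives > 25000 nM, again only a limit. In this assay compound 3 gives > 25000 nM, also a limit. Compound 3 differs from compound 1 by sec-butyl in place of isobutyl on an amine nitrogen. The resulting step, a step that the two limits leave unreadable from compound 1 to compound 3, cannot be read because both ends sit at the limit of > 25000 nM in this assay, at which 3 of the 3 values shown sit. Compound 4 `CCC(C)NC(=C\C(=O)/C=C/c1ccc(OC(C)=O)c(OC)c1)/C=C/c1ccc(OC(C)=O)c(OC)c1` has not yet been tested. It stands to compound 2 as compound 3 stands to compound 1: sec-butyl in place of isobutyl on an amine nitrogen, the same change at the same place. The difference between the cores of compound 1 and compound 2 is not broken down here. The step that the limit leaves unreadable from compound 2 to compound 4 is the one expected, and that expectation rests on compound 1 and compound 3 both sitting at the limit of > 25000 nM in this assay, at which 3 of the 3 values shown sit. Compound 4 is therefore estimated at 40000 nM, with a range from 25000 nM to 120000 nM, and most likely this assay will report only a limit again.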

Compound 4, half-maximal inhibitory concentration: > 25000 nM
Compound 4 ended at the assay's limit (the forecaster's own chance of this, stated with the estimate: 90%); the middle value does not contradict the limit.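

In this assay compound 4 gives > 25000 nM, which is a limit of the assay and not a number. The step from compound 2 to compound 4 cannot be read, because both ends sit at a limit: the limit of > 25000 nM in this assay, at which 4 of the 4 values shown sit.

From the compounds shown here alone, whether sec-butyl in place of isobutyl on an amine nitrogen changes inhibition at all stays open.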